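Pyridin-4-yl in place of pyridin-2-yl on compound 3

The source may report more compounds than this note shows. Statements on the series, on what has been measured and on what is new or still open speak of the compounds shown alone.

Three compounds of the series have numbers in a functional assay on NSCLC cells (Homo sapiens) for antiproliferative activity; a lower number here means a stronger inhibitor of growth, a higher number a weaker inhibitor of growth. Compound 3 `N=C(N)N/N=C/c1c(-c2ccccn2)nc2sc(Cl)cn12` gives 8710 nM. Compound 1 `Cc1cn2c(/C=N/NC(=N)N)c(-c3cccnc3)nc2s1` gives 13800 nM, which lies within the scatter of compound 3. Compound 2 `Cc1sc2nc(-c3ccccn3)c(/C=N/NC(=N)N)n2c1C` gives 18200 nM, a higher number than compound 3 and only just beyond the scatter.

The next compound to be read is compound 4 `N=C(N)N/N=C/c1c(-c2ccncc2)nc2sc(Cl)cn12`, which carries pyridin-4-yl in place of pyridin-2-yl on an aromatic carbon. The two have the same atoms, joined differently. Among the measured compounds shown here, no two measured compounds differ in one place only, so the series offers no direct measure of this change. The widest gap among the measured values, between compound 3 at 8710 nM and compound 2 at 18200 nM, barely clears the scatter. On that basis, no step beyond the scatter is expected in this assay, in either direction. The expected change is a 1.1-fold lower number from compound 3 to compound 4 (0.04 log units; within the scatter). For compound 4 the estimated value is 8000 nM, with an expected range of 3500 nM to 18000 nM.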

Compound 4, concentration for 50% growth inhibition: 6760 nM
Estimate against measurement, compound 4: 1.2-fold (0.07 log units) above, and the stated range covers the measured number.
By their numbers in this assay, from the lowest: compounds 4, 3, 1 and 2 (each within the scatter of the next, the first and the last beyond it).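

In this assay, among the compounds shown here, the exchange of pyridin-2-yl for pyridin-4-yl gives a 1.3-fold lower number from compound 3 to compound 4 (0.11 log units; within the scatter) and is the first comparison that differs in one place only. It shows that, on this aromatic carbon of the five-membered ring and with the rest of compound 3 unchanged, these two pyridine isomers cannot be told apart by this read-out, so the attachment point of the pyridine ring is not yet a lever on growth inhibition in this pair. For the compounds shown here, no measurement at hand accounts for this result, and the single pair gives no ground for extending it to other members.

Still open, going by these compounds, is whether this position tolerates any larger change, for example a phenyl ring, which has no ring nitrogen, or a saturated ring such as piperidin-4-yl, and whether either would move the number beyond the scatter. Also open, on these data alone, is whether the same exchange reads alike on cores with methyl groups, as in compound 1 and compound 2, since neither of those has a partner differing from it in one place.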